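Swapping a chlorophenyl for a styryl group on a pyrazoline core

The source may hold more compounds than are shown below. What is called first, only, known or untested is meant among the compounds shown, and "the series" means these compounds.

Measured so far:
Compound 1 `Cc1cc(O)c(C2=NN(c3ccc(S(N)(=O)=O)cc3)C(c3ccccc3O)C2)cc1Cl`: 14500 nM
Compound 2 `Cc1cc(O)c(C2=NN(c3ccc(S(N)(=O)=O)cc3)C(c3ccccc3Cl)C2)cc1Cl`: 20500 nM

In a functional assay on A498 cells (Homo sapiens) for antiproliferative activity, with a stated time of 48 h (on this read-out lower numbers stand for stronger inhibition of growth and higher numbers for weaker inhibition of growth), compound 2 gives 20500 nM and stands alongside compound 1, because a 1.4-fold higher number from compound 1 to compound 2 (0.15 log units; within the scatter) lies within the scatter. Compound 3 `Cc1cc(O)c(C2=NN(c3ccc(S(N)(=O)=O)cc3)C(/C=C/c3ccccc3)C2)cc1Cl` differs from compound 2 by 2-phenylethenyl in place of 2-chlorophenyl on a saturated ring carbon. For the measured compounds named here, the only measured step, from compound 1 to compound 2, concerns a different change and was within the scatter; nothing measured bears directly on this swap. No shift beyond the scatter is therefore expected for compound 3, estimated at 18000 nM (range 6000 nM to 60000 nM), which is expected to mean a 1.1-fold lower number from compound 2 to compound 3 (0.06 log units; within the scatter).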

Compound 3, concentration for total growth inhibition: 42400 nM
Estimate against measurement, compound 3: 2.4-fold (0.37 log units) below, within the range that was stated.
By their numbers in this assay, from the lowest: compounds 1 and 2 (each within the scatter of the next); then compound 3.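

In this assay, for the compounds shown here, this saturated ring carbon gives the first steps beyond the scatter when 2-phenylethenyl enters: a 2.1-fold higher number from compound 2 to compound 3 (0.32 log units; beyond the scatter) and a 2.9-fold higher number from compound 1 to compound 3 (0.47 log units; beyond the scatter), both modest. Among these three compounds, growth inhibition is therefore weaker with 2-phenylethenyl than with either 2-chlorophenyl or 2-hydroxyphenyl on this carbon. No measurement here accounts for the shift.

Still open, going by these compounds, is how an unsubstituted phenyl, a saturated 2-phenylethyl chain or an amine would fare at this carbon. It is also unclear whether the double bond or the longer link matters more.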